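A few compounds are considered here, and "the series" means these few. Any claim that something is new, unique, unknown or untested is made for them only; others in the source may bear on it.

Measured in an ADME assay on BJ cells (Homo sapiens), read by MTT assay, with a stated time of 72 h; a higher number here means a weaker inhibitor, a lower number a stronger inhibitor:
Compound 1 `COc1ncnc2c1c(I)cn2[C@@H]1O[C@H](CO)[C@@H](O)[C@H]1O` — 91000 nM.
Compound 2 `COc1nc(N)nc2c1c(-c1ccccc1)cn2[C@@H]1O[C@H](CO)[C@@H](O)[C@H]1O` — a limit of the assay, > 100000 nM.
Compound 3 `COc1ncnc2c1c(-c1ccccc1)cn2[C@@H]1O[C@H](CO)[C@@H](O)[C@H]1O` — a limit of the assay, > 100000 nM.

Compound 3 thus gives no number in this assay, only a limit; the limit of > 100000 nM in this assay, at which 2 of the 3 values shown sit, covers two of the three values shown. Of the measured steps, an at least 1.0-fold higher number from compound 1 to compound 3 (0.04 log units; that floor lies within the scatter) and a step that the two limits leave unreadable from compound 2 to compound 3. Compound 4 `CNc1ncnc2c1c(-c1ccccc1)cn2[C@@H]1O[C@H](CO)[C@@H](O)[C@H]1O` carries methylamino in place of methoxy on an aromatic carbon. Among the measured compounds shown here, no measured step touches this change, so there is nothing here to set its size or direction; the series as a whole sits at or near the limit. Compound 4 is expected at 100000 nM, range 40000 nM to 250000 nM, in this assay. The expected step of a number no higher from compound 3 to compound 4 (the limit leaves the size open) is taken as none beyond the scatter, and a limit rather than a number is the likelier outcome.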

Compound 4, half-maximal inhibitory concentration: > 100000 nM
Compound 4 gave a limit, no number (the forecaster's own chance of this, stated with the estimate: 65%); the middle value lies on the limit itself.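

No step can be read between compound 3 and compound 4, since both give a limit rather than a number: the limit of > 100000 nM in this assay, at which 3 of the 4 values shown sit.

On these data alone, whether methylamino in place of methoxy shifts the reading in this assay stays open, as does any order among compound 2, compound 3 and compound 4.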